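The compounds below may be only part of what the source reports. "The series", "measured", "known", "first", "only" and "open" are said of these compounds alone.

Compound 1 `COc1cc2ncnc(NNC(=S)NC(=O)c3ccccc3)c2cc1OC` gives 3770 nM in a functional assay on KB cells (Homo sapiens) for cytotoxicity, read by MTT assay, with a stated time of 72 h; a lower number here means a stronger inhibitor, a higher number a weaker inhibitor. Compound 2 `COc1cc2ncnc(NNC(=S)NC(=O)c3ccccc3Cl)c2cc1OC` gives 3560 nM. Compound 3 `COc1cc2ncnc(NNC(=S)NC(=O)c3ccc(C)cc3)c2cc1OC` gives 24200 nM.

Among these three, compound 3 shows the highest number, reached through a 6.4-fold higher number from compound 1 to compound 3 (0.81 log units; beyond the scatter) and a 6.8-fold higher number from compound 2 to compound 3 (0.83 log units; beyond the scatter). Compound 4 `COc1cc2ncnc(NNC(=S)NC(=O)c3ccccc3OC)c2cc1OC` differs from compound 3 by 2-methoxyphenyl in place of 4-methylphenyl on a carbonyl carbon. The two steps leading into compound 3 both bear on this change, since each removed the 4-methylphenyl's absence and produced a modest rise; by contrast a 1.1-fold lower number from compound 1 to compound 2 (0.02 log units; within the scatter) shows that a chloro entering the aromatic ring of compound 1 changed nothing beyond the scatter. Taking the 4-methylphenyl away is therefore expected to return compound 4 toward the level of compounds 1 and 2, with a step of a 6.4-fold lower number from compound 3 to compound 4 (0.80 log units; beyond the scatter) expected. Compound 4 is estimated at 3800 nM, within 1500 nM to 10000 nM.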

Compound 4, half-maximal inhibitory concentration: 3850 nM
Compound 4: the middle estimate sits 1.0-fold (0.01 log units) below what was measured, within the range that was stated.
By their numbers in this assay, from the lowest: compounds 2, 1 and 4 (each within the scatter of the next); then compound 3.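

In this assay, 2-methoxyphenyl in place of 4-methylphenyl on the carbonyl carbon brings a clear drop, with a 6.3-fold lower number from compound 3 to compound 4 (0.80 log units; beyond the scatter). Methoxy cannot be told apart from hydrogen, with a 1.0-fold higher number from compound 1 to compound 4 (0.01 log units; within the scatter), or from chloro, with a 1.1-fold higher number from compound 2 to compound 4 (0.03 log units; within the scatter), so among these compounds only compound 3 stands apart. Nothing available explains this difference. As far as these compounds go, whether compound 3 stands apart through the methyl group itself or through where it sits remains open. So does whether an amine or a carboxylic acid on the phenyl ring would stay at the level of compound 4.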